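A few compounds are considered here, and "the series" means these few. Any claim that something is new, unique, unknown or untested is made for them only; others in the source may bear on it.

Working notes on the series. Compound 1 `N#Cc1cccnc1N1CCN([C@@H]2CN[C@H](C(=O)N3CCSC3)C2)CC1` gives 1.2 nM in an assay on a cell-free system (plasma) for inhibition of Dipeptidyl peptidase 4 (Rattus norvegicus), read by fluorescence; a higher number here means a weaker inhibitor, a lower number a stronger inhibitor. Going by the values given here, compound 2 `O=C([C@@H]1C[C@H](N2CCN(c3ccccn3)CC2)CN1)N1CCSC1` gives 3.5 nM in this assay, the higher of the two numbers so far; the only measured step, a 2.9-fold higher number from compound 1 to compound 2 (0.46 log units; beyond the scatter), is modest. Compound 3 `O=C([C@@H]1C[C@H](N2CCN(c3ccc(Br)cc3)CC2)CN1)N1CCSC1` is not yet measured; it differs from compound 2 by 4-bromophenyl in place of pyridin-2-yl on an amine nitrogen in a ring. Among the compounds with values here, no measured step covers this change, so the expectation rests on the change itself and is loose; the step from compound 2 to compound 3 is expected to be a 4.3-fold higher number from compound 2 to compound 3 (0.63 log units; beyond the scatter) in this assay, towards a higher number. Compound 3 is therefore estimated at 15 nM, within 3 nM to 80 nM.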

Compound 3, half-maximal inhibitory concentration: 9 nM
Beside the measured number, compound 3's estimate is 1.7-fold (0.22 log units) above it, within the range that was stated.
By their numbers in this assay, from the lowest: compound 1; then compound 2; then compound 3.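

In this assay, this place on the amine nitrogen in a ring still accepts an aromatic ring of carbon only: 4-bromophenyl in place of pyridin-2-yl gives a 2.6-fold higher number from compound 2 to compound 3 (0.41 log units; beyond the scatter). Set against 3-cyanopyridin-2-yl, the same place shows a 7.5-fold higher number from compound 1 to compound 3 (0.88 log units; beyond the scatter), the largest step in the series so far, and compound 3 has the highest number of the three. No supporting information bears on the cause of these steps.

As far as these compounds go, what plain phenyl or pyrimidin-2-yl would give at this nitrogen remains open. The effects of the ring nitrogen and the bromine therefore cannot yet be separated.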